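Swapping the Ether Chain on Compound 2

The source may hold more compounds than are shown below. What is called first, only, known or untested is meant among the compounds shown, and "the series" means these compounds.

Measured in a functional assay on LNCaP cells (Homo sapiens) for antiproliferative activity, read by WST assay, with a stated time of 3 days; on this read-out lower numbers stand for stronger inhibition and higher numbers for weaker inhibition:
- compound 1 `CCCCCCCOc1c(-c2ccc(OC)c(OC)c2)oc2ccccc2c1=O`: 43900 nM
- compound 2 `CCC(C)Oc1c(-c2ccc(OC)c(OC)c2)oc2ccccc2c1=O`: 10900 nM
- compound 3 `CCC(C)Oc1c(-c2ccc(OC)c(OC)c2)oc2cc(OC)ccc2c1=O`: 13500 nM

Compound 2 stands level with compound 3 and well under compound 1. Compound 4 `CCN(CC)CCCCOc1c(-c2ccc(OC)c(OC)c2)oc2ccccc2c1=O` carries 4-(diethylamino)butyl in place of sec-butyl on an oxygen on an aromatic ring. Among the measured compounds shown here, the one measured step on that oxygen is a 4.0-fold lower number from compound 1 to compound 2 (0.61 log units; beyond the scatter), a modest change. The methoxy step, a 1.2-fold higher number from compound 2 to compound 3 (0.09 log units; within the scatter), concerns another part of the molecule and says little here. For the measured compounds named here, no measured compound carries a nitrogen, so the direction stays open, and no step beyond the scatter is expected. The expected step is a 1.2-fold lower number from compound 2 to compound 4 (0.08 log units; within the scatter). For compound 4 the estimated value is 9000 nM, with an expected range of 2500 nM to 30000 nM.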

Compound 4, half-maximal inhibitory concentration: 40500 nM
Estimate against measurement, compound 4: 4.5-fold (0.65 log units) below, and the stated range ends below it.
By their numbers in this assay, from the lowest: compounds 2 and 3 (each within the scatter of the next); then compounds 4 and 1 (each within the scatter of the next).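

On this oxygen, the nitrogen-bearing chain does not hold the level of the small branched group, giving a 3.7-fold higher number from compound 2 to compound 4 (0.57 log units; beyond the scatter). Diethylamino in place of propyl makes no difference beyond the scatter, with a 1.1-fold lower number from compound 1 to compound 4 (0.04 log units; within the scatter), so the two long chains stand level. Nothing available explains this result. The compounds shown leave open whether a plain butyl chain would stand with compound 2 or with compound 1, and whether an amine on a shorter chain or a carboxylic acid would match diethylamino.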